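This account rests on a few compounds, and the source may have more. Where it says the series, first, only, none or still open, it means among the compounds named here.

In a functional assay on NCI-H460 cells (Homo sapiens) for inhibition, with a stated time of 72 h (on this read-out higher numbers stand for weaker inhibition and lower numbers for stronger inhibition), three compounds that share a core and differ in one attached group have been measured. Compound 1 `COc1ccc(S(=O)(=O)N2CCc3cccc(-c4ccco4)c32)cc1` gives 94.5 nM, compound 2 `COc1ccc(S(=O)(=O)N2CCc3cccc(-c4ccc(N(C)C)cc4)c32)cc1` gives 556 nM, and compound 3 `COc1ccc(S(=O)(=O)N2CCc3cccc(-c4cc(OC)c(OC)c(OC)c4)c32)cc1` gives 6340 nM, which puts compound 2 in the middle. Compound 4 `COc1ccc(S(=O)(=O)N2CCc3cccc(-c4ccc(O)cc4)c32)cc1` carries hydroxy in place of dimethylamino on an aromatic carbon, para to a large group: hydroxy in place of dimethylamino on an aromatic carbon. Going by the values given here, the only measured step at this site, a 5.9-fold higher number from compound 1 to compound 2 (0.77 log units; beyond the scatter), replaced the whole group, whereas here the six-membered ring stays. Among the compounds with values here, no measured pair shows this smaller swap alone, so a shift within the scatter is expected, with no firm direction: a 1.2-fold lower number from compound 2 to compound 4 (0.09 log units; within the scatter). For compound 4 the estimated value is 450 nM, with an expected range of 90 nM to 2200 nM.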

Compound 4, half-maximal inhibitory concentration: 114 nM
Compound 4: middle estimate off by 3.9-fold (0.60 log units), on the high side; measured number inside the range.
By their numbers in this assay, from the lowest: compounds 1 and 4 (each within the scatter of the next); then compound 2; then compound 3.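

Exchanging only dimethylamino for hydroxy, with the six-membered ring kept, is enough to change the result beyond the scatter: a 4.9-fold lower number from compound 2 to compound 4 (0.69 log units; beyond the scatter). The ring in compound 2 therefore does not by itself set its number, and the group on that ring counts; compound 4 also sits level with the furan-2-yl compound: a 1.2-fold higher number from compound 1 to compound 4 (0.08 log units; within the scatter). No measurement shown explains why this swap has such an effect. Going by these compounds, whether a primary amine or a carboxylic acid on the same ring carbon would match hydroxy remains open.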